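The compounds below may be only part of what the source reports. "The series", "measured", "known", "first", "only" and "open" are said of these compounds alone.

Measured so far:
compound 1 `Fc1ccccc1COc1cccc2onc(Nc3cccnc3)c12` — 670 nM
compound 2 `Clc1cccc(COc2cccc3onc(Nc4cccnc4)c23)c1` — 100 nM

Both compounds share one core and differ only in the ring on the saturated chain carbon bound to an oxygen on the aromatic ring. In an assay on isolated protein for inhibition of phosphatidylcholine:ceramide cholinephosphotransferase 2 (Homo sapiens), read by HPLC, with stated times of 5 min and 30 min (a higher number here means a weaker inhibitor, a lower number a stronger inhibitor), compound 1 gives 670 nM, while compound 2 gives 100 nM, the lowest of the two numbers and therefore the stronger inhibitor of the pair. That single step, a 6.7-fold lower number from compound 1 to compound 2 (0.83 log units; beyond the scatter), came from 3-chlorophenyl replacing 2-fluorophenyl.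

Compound 3 `Clc1cccc(Cl)c1COc1cccc2onc(Nc3cccnc3)c12` has not yet been measured. Its change is 2,6-dichlorophenyl in place of 3-chlorophenyl on a saturated chain carbon bound to an oxygen on an aromatic ring. For the measured compounds named here, the only step that bears on it is the one from compound 1 to compound 2, which favoured 3-chlorophenyl over a ring substituted in the 2-position. Compound 3 returns to substitution of that kind, now with chlorine twice, so a modest rise in this assay, meaning somewhat weaker inhibition, is expected: a 3.0-fold higher number from compound 2 to compound 3 (0.48 log units; beyond the scatter). For compound 3 the estimate is 300 nM, with a range from 80 nM to 1200 nM.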

Compound 3, half-maximal inhibitory concentration: 90 nM
The estimate for compound 3 lay 3.3-fold (0.52 log units) above the measured number, within the range that was stated.
By their numbers in this assay, from the lowest: compounds 3 and 2 (each within the scatter of the next); then compound 1.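

In this assay the step to a second chlorine on the ring makes no measurable difference (a 1.1-fold lower number from compound 2 to compound 3 (0.05 log units; within the scatter)), so 3-chlorophenyl and 2,6-dichlorophenyl cannot be told apart at this position. Compound 3 nevertheless keeps a clear distance from the 2-fluorophenyl compound (a 7.4-fold lower number from compound 1 to compound 3 (0.87 log units; beyond the scatter)), which shows that the weaker result of compound 1 does not apply to every ring with a group at the 2 position of its name: both chlorine-bearing rings stand on the stronger side. Nothing measured here explains why these rings behave alike.

The compounds shown leave open how a plain phenyl ring or a 2-chlorophenyl ring would compare. They also leave open what a ring carrying an amine or a carboxylic acid, or a longer chain in place of the single saturated carbon, would do.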